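Urea to Amide: Estimating Compound 4's Antiproliferative Readout

This account rests on a few compounds, and the source may have more. Where it says the series, first, only, none or still open, it means among the compounds named here.

Measured compounds:
- compound 1, `O=C(Nc1ccc(-n2ccc3c(NC(=O)c4ccccc4)ncnc32)cc1)Nc1ccc(Cl)c(C(F)(F)F)c1`: 6000 nM
- compound 2, `O=C(Nc1ccc(-n2ccc3c(NC(=O)c4ccccc4)ncnc32)cc1)Nc1cccc(Cl)c1Cl`: 7800 nM
- compound 3, `O=C(Nc1ccc(-n2ccc3c(NC(=O)c4ccccc4)ncnc32)cc1)Nc1ccc(Cl)c(Cl)c1`: 4500 nM

In an ADME assay on HS27 cells (Homo sapiens) for antiproliferative activity, read by MTT assay, with a stated time of 24 h (on this read-out higher numbers stand for weaker inhibition and lower numbers for stronger inhibition), compound 3 gives the lowest of the three numbers, but its steps to the others, a 1.3-fold lower number from compound 1 to compound 3 (0.12 log units; within the scatter) and a 1.7-fold lower number from compound 2 to compound 3 (0.24 log units; within the scatter), both fall within the scatter, so the three compounds cannot be ranked against one another. The step to compound 4, `O=C(Nc1ccc(-n2ccc3c(NC(=O)c4ccccc4)ncnc32)cc1)c1cccc(C(F)(F)F)c1`, is 3-(trifluoromethyl)phenyl in place of (3,4-dichlorophenyl)amino on a carbonyl carbon. This is a different kind of change from those measured so far: the measured steps, including a 1.3-fold higher number from compound 1 to compound 2 (0.11 log units; within the scatter), only swapped substituents on the aryl ring while keeping the urea linkage, and all stayed within the scatter. Going by the values given here, no measured step removes the amino part of the urea, so nothing in this set shows what that removal does. The expectation therefore rests on the cluster of measured values, with a wide range to cover the untested change, and the estimated step of a 2.0-fold higher number from compound 3 to compound 4 (0.30 log units; within the scatter) is given as a modest move upward. Compound 4 is expected to give about 9000 nM, within a range of 3000 nM to 30000 nM.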

Compound 4, half-maximal inhibitory concentration: 5900 nM
Beside the measured number, compound 4's estimate is 1.5-fold (0.18 log units) above it; low and high end bracket the measured number.
By their numbers in this assay, from the lowest: compounds 3, 4, 1 and 2 (each within the scatter of the next).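

Taking the amino part out of the urea and putting 3-(trifluoromethyl)phenyl directly on the carbonyl carbon gives no step beyond the scatter in this assay: a 1.3-fold higher number from compound 3 to compound 4 (0.12 log units; within the scatter), a 1.3-fold lower number from compound 2 to compound 4 (0.12 log units; within the scatter) and a 1.0-fold lower number from compound 1 to compound 4 (0.01 log units; within the scatter). The group that leaves counts 1 hydrogen-bond donor and the group that enters counts 0, so this read-out does not tell the urea compounds from the amide compound 4, a wider change than the ring swaps among compounds 1, 2 and 3. Nothing available explains this result.

The ring substituents differ along with the link, so the link alone is not isolated by any of these steps. Also open, on these data alone, is what a group without an aromatic ring, such as a longer alkyl chain or a simple amine, would do on this carbonyl carbon.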